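This account rests on a few compounds, and the source may have more. Where it says the series, first, only, none or still open, it means among the compounds named here.

Among the compounds with values here, in a functional assay (aorta) with Rattus norvegicus as the target (on this read-out higher numbers stand for an effect only at larger amounts of compound and lower numbers for an effect already at smaller amounts), compound 1 `COc1ccc(-c2nc(N=C(N)N)sc2-c2ccc(OC)cc2)cc1` gives 2 uM, the lower of the two numbers so far, and compound 2 `COc1ccc(-c2nc(/N=C(\N)N(C)C)sc2-c2ccc(OC)cc2)cc1` gives 4.8 uM. Compound 3 `C/N=C(/NC)Nc1nc(-c2ccc(OC)cc2)c(-c2ccc(OC)cc2)s1` keeps the core of compound 1 with one change: a group of 6 heavy atoms (3 carbon, 3 nitrogen; no ring) in place of a group of 4 heavy atoms (1 carbon, 3 nitrogen; no ring), on an aromatic carbon. Within the data shown here, the one measured step that bears on this is a 2.4-fold higher number from compound 1 to compound 2 (0.38 log units; beyond the scatter), a modest change with the same counted exchange of groups, although the entering group in compound 3 is arranged differently. A step of similar size, towards a higher number, is therefore expected in this assay. For compound 3 the expected value is 5 uM, within a range of 2 uM to 12 uM. This estimate means an expected 2.5-fold higher number from compound 1 to compound 3 (0.40 log units; beyond the scatter).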

Compound 3, concentration for half-maximal effect: 2.4 uM
For compound 3 the middle estimate is 2.1-fold (0.32 log units) above the measured one; measured number inside the range.
By their numbers in this assay, from the lowest: compounds 1, 3 and 2 (each within the scatter of the next, the first and the last beyond it).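

In this assay, the aromatic carbon carrying the group takes a group of 6 heavy atoms with no step beyond the scatter when it is arranged as in compound 3 (a 1.2-fold higher number from compound 1 to compound 3 (0.08 log units; within the scatter)). The earlier pair had the same counted exchange and a step beyond the scatter, so the atom count alone does not fix the number, while the two arrangements themselves remain within the scatter (a 2.0-fold lower number from compound 2 to compound 3 (0.30 log units; within the scatter)). Nothing measured here explains this difference.

The compounds shown leave open how an amine or a longer chain would read on this aromatic carbon. They also leave open whether the picture holds with phenyl in place of the two 4-methoxyphenyl groups.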